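Swapping oxan-4-yl for 3-(methylsulfonyl)phenyl on compound 2

The source may report more compounds than this note shows. Statements on the series, on what has been measured and on what is new or still open speak of the compounds shown alone.

In a physicochemical assay for solubility, in phosphate buffer, at pH 6.5 (a higher number here means a more soluble compound, a lower number a less soluble compound), compound 1 `CNc1nc(NCCN2CCNCC2)c2sc(-c3ccc(C(F)(F)F)cc3)cc2n1` gives 115 ug/mL. Compound 2 `CNc1nc(NC2CCOCC2)c2sc(-c3ccc(C(F)(F)F)cc3)cc2n1` gives < 5 ug/mL, which is a limit of the assay and not a number. Compound 2 therefore sits on (the limit of < 5 ug/mL in this assay, at which 1 of the 2 values shown sits), so its true value is not known.

Compound 3 `CNc1nc(Nc2cccc(S(C)(=O)=O)c2)c2sc(-c3ccc(C(F)(F)F)cc3)cc2n1` keeps the core of compound 2 but carries 3-(methylsulfonyl)phenyl in place of oxan-4-yl on a nitrogen on an aromatic ring. The leaving and the entering group both have no net charge.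

Going by the values given here, only one measured step bears on this change. It alters the same place, and an at least 23-fold lower number from compound 1 to compound 2 (1.36 log units; beyond the scatter) is large and beyond the scatter. That step starts from 2-(piperazin-1-yl)ethyl, however, and that group plays no part here. With compound 2 at < 5 ug/mL as the starting point, no change beyond the scatter is expected in this assay, and no direction is favoured. The expected step is a step that the limit leaves unreadable from compound 2 to compound 3. A result that is again only a limit is likely. For compound 3 the estimated value is 4 ug/mL, with an expected range from 2 ug/mL to 10 ug/mL.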

Compound 3, solubility: < 5 ug/mL
Compound 3 gave a limit, no number (the forecaster's own chance of this, stated with the estimate: 70%); the middle value does not contradict the limit.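

In this assay, placing 3-(methylsulfonyl)phenyl instead of 2-(piperazin-1-yl)ethyl on this nitrogen gives an at least 23-fold lower number from compound 1 to compound 3 (1.36 log units; beyond the scatter), so the large step seen with oxan-4-yl is not confined to that one group. A non-aromatic ring with no net charge and an aromatic ring with no net charge, differing in size and in hydrogen-bond acceptors, now both fail to reach a readable number here. The step between compound 2 and compound 3 cannot be read, and both results now rest on the same limit of the assay: the limit of < 5 ug/mL in this assay, at which 2 of the 3 values shown sit.

Any real difference between oxan-4-yl and 3-(methylsulfonyl)phenyl therefore stays hidden, and it also remains open which part of 2-(piperazin-1-yl)ethyl goes with the much higher number of compound 1. A plain 2-aminoethyl chain, or a chain ending in a carboxylic acid, on this nitrogen would show whether a readable number can return without the piperazin-1-yl part.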